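The source may hold more compounds than are shown below. What is called first, only, known or untested is meant among the compounds shown, and "the series" means these compounds.

Of the compounds shown here, three have been measured in a functional assay on MCF7 cells (Homo sapiens) for cytotoxicity, read by CCK-8 assay, with a stated time of 24 h; on this read-out lower numbers stand for stronger inhibition and higher numbers for weaker inhibition. Compound 1, `C/C(=C\c1cc(-c2ccc(F)cc2)cs1)C(N)=O`, gives 1440 nM. Compound 3, `C/C(=C\c1cccc(-c2ccc(C)cc2)c1)C(N)=O`, gives 6710 nM. For compound 2, `C/C(=C\c1nc(-c2ccc(C)cc2)cs1)C(N)=O`, the read-out is a limit of the assay rather than a number, > 50000 nM. Among the two numbers shown, compound 1 has the lowest, and compound 3 comes nearest with a higher number; that gap lies beyond the usual scatter, but since these two compounds differ in more than one place, no single step can be drawn between them.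

The next compound, compound 4, `C=Cc1ccc(-c2csc(/C=C(\C)C(N)=O)c2)cc1`, is reached from compound 1 by one change: vinyl in place of fluoro on an aromatic carbon. Among the compounds with values here, no measured pair shows this exchange, so no measured step guides the expectation. In this assay the expected change is a 1.0-fold higher number from compound 1 to compound 4 (0.02 log units; within the scatter), small and not clearly beyond the scatter in either direction. Compound 4 is therefore estimated at 1500 nM, within a range from 500 nM to 5000 nM.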

Compound 4, half-maximal inhibitory concentration: > 50000 nM
Compound 4: no number, only a limit; the forecaster's own chance of this, stated with the estimate: 5%; middle value at least 33-fold (1.52 log units) away from the limit.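

Within the data shown here, exchanging fluoro for vinyl on this aromatic carbon, para to a large group, is the first single change that can be read, and it gives an at least 34-fold higher number from compound 1 to compound 4 (1.54 log units; beyond the scatter). A small exchange at this one position can therefore go with a large loss of activity in this assay, which compound 1, compound 2 and compound 3 could not show, as they differ from each other in more than one place. The true size of the step stays unknown, as compound 4 carries a limit of the assay and not a number: the limit of > 50000 nM in this assay, at which 2 of the 4 values shown sit.

The compounds shown leave open whether the loss belongs to vinyl alone or extends to other groups at this position, such as an amine, a methoxy group or an ethyl group. They also leave open whether such a group would keep a value close to that of compound 1 on the same core.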